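One Added Methyl on a Saturated Chain

This account rests on a few compounds, and the source may have more. Where it says the series, first, only, none or still open, it means among the compounds named here.

In a functional assay on A549 cells (Homo sapiens) for antiproliferative activity, read by MTT assay, with a stated time of 48 h (a lower number here means a stronger inhibitor, a higher number a weaker inhibitor), compound 1 (`CCCCCCC1(O)C(=O)Nc2ccc(Nc3ccc(OC)cc3)cc21`) gives 18600 nM. Compound 2 (`CCCCCC1(O)C(=O)Nc2ccc(Nc3ccc(C)cc3)cc21`) gives 8100 nM, the lower of the two numbers, by a gap beyond the usual scatter. Compound 3 (`CCCCCCC1(O)C(=O)Nc2ccc(Nc3ccc(C)cc3)cc21`) is compound 2 with one change: methyl in place of hydrogen on a saturated chain carbon, five bonds along the chain from a saturated ring carbon. This places methyl in place of hydrogen on a saturated chain carbon, five bonds along the chain from a saturated ring carbon. Going by the values given here, no measured pair shows this change alone, so only a cautious guess is possible. In this assay, the expected 1.0-fold higher number from compound 2 to compound 3 (0.02 log units; within the scatter) stays within the scatter, with no clear direction. The estimated value for compound 3 is 8500 nM, with a likely range of 4000 nM to 17000 nM.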

Compound 3, half-maximal inhibitory concentration: 12100 nM
Compound 3: the middle estimate sits 1.4-fold (0.15 log units) below what was measured; the range from low to high includes it.
By their numbers in this assay, from the lowest: compounds 2, 3 and 1 (each within the scatter of the next, the first and the last beyond it).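

Adding methyl on this saturated chain carbon brings a 1.5-fold higher number from compound 2 to compound 3 (0.17 log units; within the scatter) in this assay and so no clear shift: at this stage, the chain tolerates one more carbon. With this same chain in both compounds, methyl in place of methoxy on an aromatic carbon brings a 1.5-fold lower number from compound 1 to compound 3 (0.19 log units; within the scatter) and again no clear shift. No evidence is available to explain either result. Still open, on these data alone, is whether a much longer chain would change the number beyond the scatter. An amine or a carboxylic acid in place of this methyl also remains to be seen.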